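The source may report more compounds than this note shows. Statements on the series, on what has been measured and on what is new or still open speak of the compounds shown alone.

In a functional assay on DU-145 cells (Homo sapiens) for antiproliferative activity, read by MTT assay, with a stated time of 3 days (a lower number here means a stronger inhibitor, a higher number a weaker inhibitor), compound 1 (`COc1cc(O)c2c(=O)cc(-c3ccc(NS(C)(=O)=O)cc3)oc2c1OC(C)C`) gives 19100 nM and compound 2 (`COc1cc(O)c2c(=O)cc(-c3ccc(NS(=O)(=O)C4CC4)cc3)oc2c1OC(C)C`) gives 48700 nM, the higher of the two numbers. Compound 3 (`C=CC(=O)Nc1ccc(-c2cc(=O)c3c(O)cc(OC)c(OC(C)C)c3o2)cc1`) departs from compound 2 as follows: vinylcarbonyl in place of cyclopropylsulfonyl on a nitrogen on an aromatic ring. Going by the values given here, the only measured step bearing on this is a 2.5-fold higher number from compound 1 to compound 2 (0.41 log units; beyond the scatter). That step alters the group on the sulfonyl sulfur and keeps the sulfonyl, so it guides only loosely. A modest move towards a lower number is expected in this assay. The expected step is a 2.4-fold lower number from compound 2 to compound 3 (0.39 log units; beyond the scatter). For compound 3 the estimated value is 20000 nM, within an expected range of 5000 nM to 60000 nM.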

Compound 3, half-maximal inhibitory concentration: 14700 nM
Estimate against measurement, compound 3: 1.4-fold (0.13 log units) above, within the range that was stated.
By their numbers in this assay, from the lowest: compounds 3 and 1 (each within the scatter of the next); then compound 2.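

Working notes on the nitrogen on the aromatic ring in this assay: the sulfonyl is not needed for activity at this position, since vinylcarbonyl gives a 3.3-fold lower number from compound 2 to compound 3 (0.52 log units; beyond the scatter). Against the methylsulfonyl group the same swap gives a 1.3-fold lower number from compound 1 to compound 3 (0.11 log units; within the scatter), so these two groups cannot be told apart here. No measurement available explains either step.

Going by these compounds, whether the vinyl double bond matters remains open, as a saturated propanoyl or an acetyl group would test this. A free amine at this nitrogen would show whether any acyl or sulfonyl group is needed.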